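The source may hold more compounds than are shown below. What is called first, only, known or untested is meant among the compounds shown, and "the series" means these compounds.

Going by the values given here, in a functional assay on MCF7 cells (Homo sapiens) for cytotoxicity (on this read-out lower numbers stand for stronger inhibition of growth and higher numbers for weaker inhibition of growth), compound 1 `COc1ccc(NS(=O)(=O)c2cc(F)c(F)c(F)c2F)cc1` gives 120 nM, the lower of the two numbers measured so far. Among the compounds with values here, the only other measured compound, compound 2 `COc1ccc(NS(=O)(=O)c2cc(F)c(F)c(F)c2)cc1`, gives 2000 nM. Compound 3 `COc1ccc(NS(=O)(=O)c2ccc(F)c(F)c2F)cc1` has not yet been measured. It departs from compound 1 by one change, (hydrogen in place of fluoro on an aromatic carbon). Within the data shown here, the single measured step bearing on this is of the same kind, hydrogen in place of fluoro on an aromatic carbon, and it is large: a 17-fold higher number from compound 1 to compound 2 (1.22 log units; beyond the scatter). However, that step concerns a different carbon of the ring, and no measurement yet shows what replacing the fluoro at this place does. The earlier step therefore sets the direction more firmly than the size. A higher number is expected in this assay, most likely beyond the scatter but smaller than the measured step, although a step of similar size cannot be ruled out. The estimated step is a 4.2-fold higher number from compound 1 to compound 3 (0.62 log units; beyond the scatter). For compound 3 the expected value is 500 nM, with an estimated range from 150 nM to 2000 nM.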

Compound 3, concentration for 50% growth inhibition: > 50000 nM
Compound 3 gave a limit, no number; the forecaster's own chance of this, stated with the estimate: 3%; at least 100-fold (2.00 log units) between middle value and limit.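

The exchange of fluoro for hydrogen does not weigh the same on every carbon of this ring: at this place, meta to a large group and ortho to a fluoro group, it gives an at least 410-fold higher number from compound 1 to compound 3 (2.61 log units; beyond the scatter) in this assay while the same exchange on a different carbon gave a 17-fold higher number from compound 1 to compound 2 (1.22 log units; beyond the scatter) and still left a measurable number. For compound 3 the reading of > 50000 nM is a limit of the assay and not a number: the limit of > 50000 nM in this assay, at which 1 of the 3 values shown sits. Of the two fluoro groups removed so far, the one at this place is therefore the one whose loss costs more in this assay, and the step to compound 2 alone gave no sign of how much the growth inhibition of compound 1 depends on it.

On these data alone, how far the loss truly extends stays open, since the limit marks only where the reading stops and gives no end point for the step. As far as these compounds go, it also remains open whether this place requires fluoro itself or would tolerate another substituent such as a chlorine atom, a methyl group, a nitrile or an amine, and what removing each remaining fluoro group would do.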